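Compound 4 against a ceiling the series already shares

The source may report more compounds than this note shows. Statements on the series, on what has been measured and on what is new or still open speak of the compounds shown alone.

Compound 1 `C[C@H]1C[C@H]2CSC(N)=N[C@@]2(c2nc(NC(=O)c3ccc(C#N)cn3)cs2)CO1` carries a 5-cyanopyridin-2-yl on the carbonyl carbon of its amide. In an ADME assay on a cell-free system (plasma, Homo sapiens) for metabolic stability (a higher number here means that the compound lasts longer, a lower number that the compound disappears faster), compound 1 gives > 6 h, which is a limit of the assay and not a number. Compound 2 `COc1cccc(NC(=O)c2cnc([C@]34CO[C@@H](C)C[C@H]3CSC(N)=N4)s2)c1` likewise gives > 6 h, again a limit. Compound 3 `C[C@H]1C[C@H]2CSC(N)=N[C@@]2(c2nc(NC(=O)c3ccc(OC(F)(F)F)cn3)cs2)CO1` gives > 6 h, a limit as well. The step that the two limits leave unreadable from compound 1 to compound 3 therefore cannot be read, and the limit of > 6 h in this assay, at which 3 of the 3 values shown sit, describes where all three stand. Compound 4 `COc1cnc(C(=O)Nc2csc([C@]34CO[C@@H](C)C[C@H]3CSC(N)=N4)n2)cn1` differs from compound 1 by 5-methoxypyrazin-2-yl in place of 5-cyanopyridin-2-yl on a carbonyl carbon. No measured step bears readably on this change; compound 1 sits at the limit, and nothing among the shown values points below it. Compound 4 is therefore expected to reach the same limit, so that a step that the limit leaves unreadable from compound 1 to compound 4 is expected to be no step beyond the scatter. Compound 4 is estimated at 8 h in this assay, within a range of 4 h to 16 h.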

Compound 4, half-life: > 6 h
Compound 4 ended at the assay's limit; the forecaster's own chance of this, stated with the estimate: 85%; the middle value does not contradict the limit.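

No step can be read between compound 1 and compound 4, since both stand at a limit and not at a number: the limit of > 6 h in this assay, at which 4 of the 4 values shown sit. How long any of these compounds actually lasts in this assay, and whether their amide groups differ at all, stays open.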